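Fluoro to Chloro on Two Related Oxadiazole Cores

A few compounds are considered here, and "the series" means these few. Any claim that something is new, unique, unknown or untested is made for them only; others in the source may bear on it.

Compound 1 `N#Cc1ccc(OCc2nnc(-c3ccc(F)cc3)o2)cc1F` was tested in an ADME assay on MCF-10A cells (Homo sapiens) for cytotoxicity, read by MTT assay, with a stated time of 48 h (a higher number here means a weaker inhibitor, a lower number a stronger inhibitor), and gives 84200 nM. Compound 2 `N#Cc1ccc(OCc2nnc(-c3ccc(Cl)cc3)o2)cc1F` carries the change (chloro in place of fluoro on an aromatic carbon). In this assay compound 2 gives only a limit of the assay, > 100000 nM. The step of an at least 1.1-fold higher number from compound 1 to compound 2 (0.07 log units; that floor lies within the scatter) therefore has only a floor. Compound 3 `Fc1ccc(-c2nnc(COc3ccc(-c4nnco4)cc3)o2)cc1` rests on a different core; the difference between the two cores is not broken down here. In this assay compound 3 gives a limit of the assay, > 100000 nM. The limit recurs: the limit of > 100000 nM in this assay, at which 2 of the 3 values shown sit. Compound 4 `Clc1ccc(-c2nnc(COc3ccc(-c4nnco4)cc3)o2)cc1`, not yet measured, differs from compound 3 by chloro in place of fluoro on an aromatic carbon, the same change as from compound 1 to compound 2. The measured step of an at least 1.1-fold higher number from compound 1 to compound 2 (0.07 log units; that floor lies within the scatter) pointed toward a higher number, so compound 4 is expected to show a step that the limit leaves unreadable from compound 3 to compound 4. Compound 4 is estimated at 130000 nM, between 60000 nM and 300000 nM.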

Compound 4, half-maximal inhibitory concentration: > 100000 nM
Compound 4 ended at the assay's limit (the forecaster's own chance of this, stated with the estimate: 85%); the middle value lies beyond the limit too.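

Compound 3 and compound 4 both rest at a limit in this assay, so no step between them can be read: the limit of > 100000 nM in this assay, at which 3 of the 4 values shown sit.

The compounds shown leave open whether chloro in place of fluoro changes the number at all on either core.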